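Removing the para-chloro from an acylhydrazone: an expectation

The compounds below may be only part of what the source reports. "The series", "measured", "known", "first", "only" and "open" are said of these compounds alone.

Of the compounds shown here, two carrying the same dimethoxystyryl core have been tested in a functional assay on SF-539 cells (Homo sapiens) for antiproliferative activity, read by sulforhodamine B assay, with a stated time of 48 h; on this read-out lower numbers stand for stronger inhibition of growth and higher numbers for weaker inhibition of growth. Compound 1 `COc1ccc(OC)c(/C=C/c2nnc(Nc3ccc(Cl)cc3)o2)c1` gives 11800 nM in this assay, while compound 2 `COc1ccc(OC)c(/C=C/C(=O)N/N=C/c2ccc(Cl)cc2)c1` gives 258 nM, the lower of the two numbers, with compound 1 standing well beyond the scatter above it. Compound 3 `COc1ccc(OC)c(/C=C/C(=O)N/N=C/c2ccccc2)c1` is not yet measured; it differs from compound 2 by hydrogen in place of chloro on an aromatic carbon. Loss of the chloro is expected to weaken growth inhibition modestly, so the step of a 1.9-fold higher number from compound 2 to compound 3 (0.29 log units; within the scatter) is estimated as a small rise that may still sit within the scatter. Compound 3 is therefore expected to give about 500 nM, within a range from 150 nM to 1800 nM.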

Compound 3, concentration for 50% growth inhibition: 4420 nM
For compound 3 the middle estimate is 8.8-fold (0.95 log units) below the measured one; measured number outside the range, above it.
By their numbers in this assay, from the lowest: compound 2; then compound 3; then compound 1.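

In this assay the change from 4-chlorophenyl to phenyl is a 17-fold higher number from compound 2 to compound 3 (1.23 log units; beyond the scatter) and shows that, on this acylhydrazone, the single chloro para to a large group carries much of the growth inhibition. The earlier pair differed in more than one place and could not isolate this position. No measurement at hand accounts for the size of the step. As far as these compounds go, whether fluoro, bromo or methyl in the same place would keep the growth inhibition stays open, and so does whether a methoxy group or an amine would.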